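The source may report more compounds than this note shows. Statements on the series, on what has been measured and on what is new or still open speak of the compounds shown alone.

Working notes on the series.

Three compounds have numbers in a functional assay on the whole organism (strain Swiss albino) for inhibition, with Mus musculus as the target, in the formalin test, with stated times of 30 min and 5 min, at a dose of 100 mg/kg; a higher number here means more inhibition at the dose given (going by the name of the read-out), a lower number less inhibition. Compound 1, `CCN1CCc2c(c(C)nn2C(=O)Nc2ccc(Br)cc2)C1`, gives 1.7%. Compound 2, `CCN1CCc2c(c(C)nn2C(=O)Nc2ccc(C)cc2C)C1`, gives 7%. Compound 3, `CCN1CCc2c(c(C(C)(C)C)nn2C(=O)Nc2c(C)cccc2C)C1`, gives 15.7%. Among the measured compounds shown here, of the three numbers, the one for compound 3 stands highest, but compound 2 lies within the usual scatter of it, so the two cannot be told apart on these data; only compound 1 lies beyond the scatter, with the lower number. All three numbers are small for a read-out of this kind.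

Compound 4, `CCN1CCc2c(c(C(C)(C)C)nn2C(=O)Nc2cc(C)ccc2F)C1`, is not yet measured. It differs from compound 3 in one place: 2-fluoro-5-methylphenyl in place of 2,6-dimethylphenyl on an amide-type nitrogen. For the measured compounds named here, no pair among the measured compounds changes only this group, so there is no step of the same sort to lean on; the three measured compounds differ in several places at once.

For compound 4 the number in this assay is therefore expected close to that of compound 3, with the step of a number 2.7 percentage points lower from compound 3 to compound 4 (within the scatter) estimated as none beyond the scatter. Compound 4 is estimated at 13%, with a range from 2% to 28%.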

Compound 4, a percentage reported as inhibition, in the whole organism at one dose (the size of the read-out at that dose, not a potency): 7%
Beside the measured number, compound 4's estimate is 6 percentage points above it; low and high end bracket the measured number.
By their numbers in this assay, from the lowest: compounds 1, 2, 4 and 3 (each within the scatter of the next, the first and the last beyond it).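

With 2-fluoro-5-methylphenyl in place of 2,6-dimethylphenyl on an amide-type nitrogen, the result in this assay is a number 8.7 percentage points lower from compound 3 to compound 4 (within the scatter), so the two groups cannot be told apart at this place. Among the compounds shown here, this is the first pair that differs in one place only, and it gives this nitrogen a direct reading that the earlier compounds, which differ in several places at once, could not give. No measurement shown here bears on what lies behind the result.

Going by these compounds, it remains open whether a group of another kind on this nitrogen, such as a pyridyl ring, a benzyl group or a phenyl ring carrying a carboxylic acid, would give a number beyond the scatter of compound 3. For the compounds shown here, the separate contribution of the tert-butyl group on the shared core also remains open, as no pair isolates it.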